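From 3-chlorophenyl to 2-methoxyphenyl on the shared core

The source may report more compounds than this note shows. Statements on the series, on what has been measured and on what is new or still open speak of the compounds shown alone.

Among the measured compounds shown here, in a functional assay on HepG2 cells (Homo sapiens) for inhibition, read by MTT assay, with a stated time of 24 h (a lower number here means a stronger inhibitor, a higher number a weaker inhibitor), compound 1 `CC1(C)[C@H]2CC[C@]1(C)N(Cc1cn(-c3cccc(F)c3)nn1)C(=O)C2` gives 80 nM and compound 2 `CC1(C)[C@H]2CC[C@]1(C)N(Cc1cn(-c3cccc(Cl)c3)nn1)C(=O)C2` gives 60 nM as the only numbers so far. For the measured compounds named here, compound 2 therefore stands level with compound 1, the single measured step being a 1.3-fold lower number from compound 1 to compound 2 (0.12 log units; within the scatter) for chloro in place of fluoro on an aromatic carbon.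

Compound 3 `COc1ccccc1-n1cc(CN2C(=O)C[C@@H]3CC[C@@]2(C)C3(C)C)nn1` differs from compound 2 by 2-methoxyphenyl in place of 3-chlorophenyl on an aromatic nitrogen with 2-methoxyphenyl in place of 3-chlorophenyl on an aromatic nitrogen of a five-membered aromatic ring with 3 nitrogen. Going by the values given here, the one measured step bears on this only loosely, since it exchanged one halogen for another. Among the compounds with values here, no compound with a methoxy group has been measured yet, and the data hold no example of a change of this kind.

In this assay no step beyond the scatter can be firmly expected, and no direction is well supported. The expected step is a 1.7-fold higher number from compound 2 to compound 3 (0.22 log units; within the scatter) as a cautious estimate. Compound 3 is estimated at 100 nM with an expected range from 30 nM to 350 nM before any measurement.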

Compound 3, half-maximal inhibitory concentration: 110 nM
The estimate for compound 3 lay 1.1-fold (0.04 log units) below the measured number; the measured number falls inside the stated range.
By their numbers in this assay, from the lowest: compounds 2, 1 and 3 (each within the scatter of the next).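

In this assay, the group on the aromatic nitrogen of the five-membered aromatic ring with 3 nitrogen now spans more than a halogen exchange: 2-methoxyphenyl in place of 3-chlorophenyl gives a 1.8-fold higher number from compound 2 to compound 3 (0.26 log units; within the scatter), and 2-methoxyphenyl in place of 3-fluorophenyl gives a 1.4-fold higher number from compound 1 to compound 3 (0.14 log units; within the scatter). Across these three compounds, this position therefore accepts a methoxy-bearing aryl group, with one hydrogen-bond acceptor in the entering group against none in 3-chlorophenyl, and neither step leaves the scatter. No supporting measurement is available to account for this result.

The swap changes both the substituent and its place on the phenyl ring, so the shown compounds cannot separate the contribution of either one. As far as these compounds go, it also remains open whether a carboxylic acid, an amine or a longer alkyl chain on that phenyl ring, or an unsubstituted phenyl, would produce a step beyond the scatter at this position.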